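Sulfonamide Substitution on a Trifluoromethyl Hydroxy Amide Core

The source may hold more compounds than are shown below. What is called first, only, known or untested is meant among the compounds shown, and "the series" means these compounds.

Of the compounds shown here, three sharing one core have been measured in an assay on a protein complex (Cavia porcellus) with sulfonylurea receptors; K-ATP channels (Homo sapiens) as the target; on this read-out higher numbers stand for weaker inhibition and lower numbers for stronger inhibition. Compound 1 `CC(O)(C(=O)Nc1ccc(-c2nn[nH]n2)cc1)C(F)(F)F` carries a 2H-tetrazol-5-yl group on the aromatic ring; in this assay compound 1 reaches only the limit > 30000 nM, which is a limit of the assay and not a number. Compound 2 `CCN(CC)C(=O)c1ccc(NC(=O)C(C)(O)C(F)(F)F)cc1` carries a diethylcarbamoyl group instead, and compound 2 likewise gives only the limit > 30000 nM. For the measured compounds named here, compound 3 `CC(O)(C(=O)Nc1ccc(S(N)(=O)=O)cc1)C(F)(F)F` carries a sulfamoyl group, and compound 3 gives 12800 nM, the only actual number among the three. The steps of an at least 2.3-fold lower number from compound 1 to compound 3 (0.36 log units; beyond the scatter) and an at least 2.3-fold lower number from compound 2 to compound 3 (0.36 log units; beyond the scatter) are both at least modest, while the step that the two limits leave unreadable from compound 1 to compound 2 cannot be read because the limit of > 30000 nM in this assay, at which 2 of the 3 values shown sit, caps both values.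

Compound 4 `CC(O)(C(=O)Nc1ccc(S(=O)(=O)N2CCOCC2)cc1)C(F)(F)F` differs from compound 3 by morpholin-4-yl in place of amino on a sulfonyl sulfur. The closest comparison is compound 2, whose diethylcarbamoyl likewise lacks a donor and sits at a limit, so a move back toward weaker inhibition is expected: compound 4 is estimated at 25000 nM, within 8000 nM to 90000 nM. That estimate means the step of a 2.0-fold higher number from compound 3 to compound 4 (0.29 log units; within the scatter) is expected.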

Compound 4, half-maximal inhibitory concentration: 5850 nM
Beside the measured number, compound 4's estimate is 4.3-fold (0.63 log units) above it; measured number below the stated range.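

In this assay, for the compounds shown here, replacing amino with morpholin-4-yl gives a 2.2-fold lower number from compound 3 to compound 4 (0.34 log units; beyond the scatter), the only step read between two actual numbers and the only change on a sulfonyl sulfur rather than on an aromatic carbon. The sulfonyl sulfur therefore carries a six-membered non-aromatic ring in place of a single nitrogen with no loss of inhibition, and the hydrogen-bond donor counted on amino is not needed for the inhibition measured in this pair. Nothing given here explains the direction of this step.

The compounds shown leave open whether the gain follows from the ring as a whole or from its oxygen. A piperidin-1-yl or a dimethylamino group on the same sulfonyl sulfur would help separate these two readings.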